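Trading alkyl chains on an imidazole substituent

The source may hold more compounds than are shown below. What is called first, only, known or untested is meant among the compounds shown, and "the series" means these compounds.

Compound 1, `Cc1n[nH]c(C)c1CN1CCN(c2cccc3[nH]c(-c4ccc(C(C)(C)C)cc4)nc23)CC1`, gives 68 nM in an assay on isolated protein for displacement of a labelled ligand from Gonadotropin-releasing hormone receptor (Homo sapiens); on this read-out higher numbers stand for weaker inhibition and lower numbers for stronger inhibition.
Compound 2, `CCc1cc(CN2CCN(c3cccc4[nH]c(-c5ccc(C(C)(C)C)cc5)nc34)CC2)nn1C`, gives 43 nM in this assay.
Compound 3, `CCCCc1nc(CN2CCN(c3cccc4[nH]c(-c5ccc(C(C)(C)C)cc5)nc34)CC2)cn1C`, gives 26 nM in this assay.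

All three share one core and differ only in the small aromatic ring attached through a saturated chain carbon to the amine nitrogen of the ring. Compound 3 gives the smallest number shown, although a 1.7-fold lower number from compound 2 to compound 3 (0.22 log units; within the scatter), while a 2.6-fold lower number from compound 1 to compound 3 (0.42 log units; beyond the scatter). Compound 4, `CCCn1cc(CN2CCN(c3cccc4[nH]c(-c5ccc(C(C)(C)C)cc5)nc34)CC2)nc1C`, keeps the same five-membered ring as compound 3 but rearranges its alkyl groups: 2-methyl-1-propyl-1H-imidazol-4-yl in place of 2-butyl-1-methyl-1H-imidazol-4-yl on a saturated chain carbon bound to an amine nitrogen in a ring. Among the compounds with values here, none of the measured steps makes this exact change; each of them swaps the whole ring for a different one. The nearest guides are the step from the ring of compound 2 to that of compound 3, a 1.7-fold lower number from compound 2 to compound 3 (0.22 log units; within the scatter), and the step between the two pyrazoles, a 1.6-fold lower number from compound 1 to compound 2 (0.20 log units; within the scatter); both show that changes of this kind shifted the numbers little. With the ring type unchanged and only the alkyl chains trading places, the step expected in this assay is small and in no clear direction, a 1.3-fold higher number from compound 3 to compound 4 (0.13 log units; within the scatter). Compound 4 is therefore estimated at 35 nM, with a likely range from 15 nM to 80 nM.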

Compound 4, half-maximal inhibitory concentration: 18 nM
The estimate for compound 4 lay 1.9-fold (0.29 log units) above the measured number; the measured number falls inside the stated range.
By their numbers in this assay, from the lowest: compounds 4, 3, 2 and 1 (each within the scatter of the next, the first and the last beyond it).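

At this place, on a saturated chain carbon bound to an amine nitrogen in a ring, 2-methyl-1-propyl-1H-imidazol-4-yl stands in for 2-butyl-1-methyl-1H-imidazol-4-yl, and this assay barely separates them (a 1.4-fold lower number from compound 3 to compound 4 (0.16 log units; within the scatter)). Against the two pyrazole groups, the new imidazole clears the scatter twice (a 2.4-fold lower number from compound 2 to compound 4 (0.38 log units; beyond the scatter) and a 3.8-fold lower number from compound 1 to compound 4 (0.58 log units; beyond the scatter)), whereas the butyl imidazole cleared it once (a 2.6-fold lower number from compound 1 to compound 3 (0.42 log units; beyond the scatter)) and stayed within it once (a 1.7-fold lower number from compound 2 to compound 3 (0.22 log units; within the scatter)). No measurement shown here explains these differences.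

Because the butyl and propyl chains also sit at different places on the imidazole, the effect of chain length cannot be told apart from the effect of where the chain sits. Going by these compounds, a hexyl chain, a cyclopropyl group, or a chain ending in an amine or a carboxylic acid would show how much more this place accepts, and whether the imidazole keeps its edge over the pyrazoles remains open.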